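Lengthening an ester side chain on a shared core

The source may report more compounds than this note shows. Statements on the series, on what has been measured and on what is new or still open speak of the compounds shown alone.

In a functional assay on MCF7 cells (Homo sapiens) for inhibition, read by MTT assay, with a stated time of 72 h (a lower number here means a stronger inhibitor of growth, a higher number a weaker inhibitor of growth), compound 1 `CC1(C)CCC[C@]2(C)[C@@H](C=O)C(C=O)=CC[C@@H]12` gives 75000 nM. Compound 2 `CCOC(=O)/C=C/C1=CC[C@H]2C(C)(C)CCC[C@]2(C)[C@H]1C=O`, with 2-(ethoxycarbonyl)ethenyl in place of formyl on a double-bonded ring carbon, gives 30000 nM. Compound 3 `CC1(C)CCC[C@]2(C)[C@@H](C=O)C(/C=C/C(=O)OCc3ccccc3)=CC[C@@H]12`, with phenyl in place of methyl in the ester group, gives 27000 nM. Compound 2 thus stands level with compound 3, and its number is under that of compound 1.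

Compound 4 `COC(=O)/C=C/C=C/C1=CC[C@H]2C(C)(C)CCC[C@]2(C)[C@H]1C=O` is still unmeasured. Its difference from compound 2 is 2-(methoxycarbonyl)ethenyl in place of ethoxycarbonyl on a double-bonded chain carbon bound to a double-bonded chain carbon. For the measured compounds named here, no measured step makes this exact change. The nearest guide is a 2.5-fold lower number from compound 1 to compound 2 (0.40 log units; beyond the scatter), a modest step that also brought in an ester-bearing ethenyl group. A change at the ester end gave a 1.1-fold lower number from compound 2 to compound 3 (0.05 log units; within the scatter), which is no real shift. The expected result is a 1.4-fold lower number from compound 2 to compound 4 (0.13 log units; within the scatter), a small move toward a lower number that would not clear the scatter. The estimated value for compound 4 is 22000 nM, with an expected range from 9000 nM to 50000 nM.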

Compound 4, concentration for 50% growth inhibition: 31000 nM
The estimate for compound 4 lay 1.4-fold (0.15 log units) below the measured number, within the range that was stated.
By their numbers in this assay, from the lowest: compounds 3, 2 and 4 (each within the scatter of the next); then compound 1.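

In this assay, putting 2-(methoxycarbonyl)ethenyl in place of ethoxycarbonyl gives a 1.0-fold higher number from compound 2 to compound 4 (0.01 log units; within the scatter), so the side chain can carry a second double bond, with a methyl ester at its end, and the number stays where it was. The first ester-bearing ethenyl group gave a 2.5-fold lower number from compound 1 to compound 2 (0.40 log units; beyond the scatter), but adding a further ethenyl unit does not repeat that shift. The data offer no explanation for this flat result.

Every side chain shown here ends in an ester, so it remains open whether a carboxylic acid or an amide at that end would move the number. Also open, as far as these compounds go, is whether an ethyl ester on this longer chain would match compound 4, or whether a still longer chain with a third double bond would hold the number steady.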